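Sulfated glycoside amides: trading the distal sulfate for phenyl

The source may hold more compounds than are shown below. What is called first, only, known or untested is meant among the compounds shown, and "the series" means these compounds.

Three compounds of the series have numbers in an assay on isolated protein for binding affinity to vascular endothelial growth factor A, long form (Homo sapiens), read by surface plasmon resonance; a lower number here means tighter binding, a higher number weaker binding. Compound 1 `CCN(CC(=O)NC[C@H]1O[C@H](OC)[C@@H](OS(=O)(=O)O)[C@@H](OS(=O)(=O)O)[C@@H]1OS(=O)(=O)O)C(=O)COS(=O)(=O)O` gives 512000 nM. Compound 2 `CCN(CC(=O)NC[C@H]1O[C@H](OC)[C@@H](OS(=O)(=O)O)[C@@H](OS(=O)(=O)O)[C@@H]1OS(=O)(=O)O)C(=O)CCCCCCCCCOS(=O)(=O)O` gives 545000 nM. Compound 3 `CCN(CC(=O)NCCO[C@H]1O[C@H](COS(=O)(=O)O)[C@@H](OS(=O)(=O)O)[C@H](OS(=O)(=O)O)[C@@H]1OS(=O)(=O)O)C(=O)CCCCCCCCCOS(=O)(=O)O` gives 50000 nM. Compound 2 holds the highest of the three numbers; compound 1 sits within the scatter of it, and compound 3 shows a clearly lower number, beyond the scatter.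

Compound 4 `CCN(CC(=O)NC[C@H]1O[C@H](OC)[C@@H](OS(=O)(=O)O)[C@@H](OS(=O)(=O)O)[C@@H]1OS(=O)(=O)O)C(=O)CCCc1ccccc1` is not yet measured. It differs from compound 2 by phenyl in place of 6-(sulfooxy)hexyl on a saturated chain carbon, three bonds along the chain from a carbonyl carbon. Among the measured compounds shown here, no single-point step between measured compounds is available, so the size of this change in this assay is untested; compound 1 and compound 2 show only that the reach of the terminal sulfooxy chain leaves the number unchanged within the scatter, which says nothing about removing that group.

The step from compound 2 to compound 4 is expected to be small, toward a somewhat higher number, estimated at a 1.5-fold higher number from compound 2 to compound 4 (0.17 log units; within the scatter). Compound 4 is expected at 800000 nM, with a range from 350000 nM to 2000000 nM, and a real chance that this assay reports only a limit.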

Compound 4, dissociation constant: 81000 nM
Compound 4: middle estimate off by 9.9-fold (0.99 log units), on the high side, and the stated range ends above it.
By their numbers in this assay, from the lowest: compounds 3 and 4 (each within the scatter of the next); then compounds 1 and 2 (each within the scatter of the next).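

In this assay, the terminal sulfooxy group is not required on this core: phenyl in place of 6-(sulfooxy)hexyl, on a saturated chain carbon, three bonds along the chain from a carbonyl carbon, gives a 6.7-fold lower number from compound 2 to compound 4 (0.83 log units; beyond the scatter) and the number does not rise. Phenethyl in place of sulfooxy on a saturated chain carbon bound to a carbonyl carbon gives a 6.3-fold lower number from compound 1 to compound 4 (0.80 log units; beyond the scatter) in the same direction, so this position responds to the identity of the chain end, which compound 1 and compound 2 could not show. Nothing measured here accounts for the lower number.

From the compounds shown here alone, whether the aromatic ring matters, or only the loss of the sulfooxy group, remains open; a cyclohexyl or unbranched hexyl end would separate the two. Also open, going by these compounds, is whether phenyl carries over to the core of compound 3.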